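Compound 2 and a Larger Group on Its Amine

The source may hold more compounds than are shown below. What is called first, only, known or untested is meant among the compounds shown, and "the series" means these compounds.

In a functional assay on the whole organism with Mus musculus as the target (a higher number here means that more compound is needed for the effect, a lower number that less compound is needed), compound 2 `C[C@@H](NCc1ccc(OCc2ccccc2)cc1)C(N)=O` gives 23.8 mg/kg as the lowest of three numbers. Compound 3 `CNC(=O)[C@H](CCSC)NCc1ccc(OCc2ccccc2)cc1` gives 239 mg/kg and sits clearly higher, while compound 1 `NC(=O)CNCc1ccccc1` gives 490 mg/kg and sits higher still. Compound 4 `CNC(=O)[C@H](NCc1ccc(OCc2ccccc2)cc1)C(C)C` differs from compound 2 through one change 2-methyl-1-(methylcarbamoyl)propyl in place of 1-carbamoylethyl on an amine nitrogen that puts 2-methyl-1-(methylcarbamoyl)propyl in place of 1-carbamoylethyl on an amine nitrogen. Within the data shown here, no measured pair shows this change alone. Compound 3 also carries a methylcarbamoyl group. The closest guide is compound 3 at 239 mg/kg, so a rise beyond the scatter seems likely. The estimated step of a 4.2-fold higher number from compound 2 to compound 4 (0.62 log units; beyond the scatter) means more compound would be needed. Compound 4 is expected at 100 mg/kg (range 35 mg/kg to 300 mg/kg) once tested.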

Compound 4, dose for half-maximal effect: 112 mg/kg
Compound 4: middle estimate off by 1.1-fold (0.05 log units), on the low side; low and high end bracket the measured number.
By their numbers in this assay, from the lowest: compound 2; then compound 4; then compound 3; then compound 1.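

On the amine nitrogen, putting 2-methyl-1-(methylcarbamoyl)propyl in place of 1-carbamoylethyl gives, in this assay, a 4.7-fold higher number from compound 2 to compound 4 (0.67 log units; beyond the scatter). This single-place comparison shows that more compound is needed with the larger group, which has 8 heavy atoms against 5. Nothing at hand explains this rise.

The swap alters both the side chain and the amide, so the step cannot be divided between them. A 1-(methylcarbamoyl)ethyl group or a 1-carbamoyl-2-methylpropyl group on the same nitrogen would separate these two parts.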